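Series notes: ring-nitrogen substituent change, compound 1 to compound 3

A few compounds are considered here, and "the series" means these few. Any claim that something is new, unique, unknown or untested is made for them only; others in the source may bear on it.

Measured so far:
compound 1 `OC[C@@H](O[C@H]1CCCN(Cc2ncc[nH]2)[C@H]1c1ccccc1)c1cc(Cl)cc(Cl)c1`: > 200000 nM
compound 2 `Cc1cc(C(=O)O)ccc1CN1CCC[C@H](O[C@H](CO)c2cc(F)cc(F)c2)[C@@H]1c1ccccc1`: > 200000 nM

Both values come from an assay on isolated protein for activation of cGMP-dependent protein kinase 1 (Homo sapiens), read by ADP-Glo, with stated times of 30 min and 2 h; a lower number here means that less compound is needed, a higher number that more compound is needed for the effect. Compound 1 gives > 200000 nM in this assay, which is a limit of the assay and not a number. Compound 2 gives > 200000 nM in this assay, also a limit. Going by the values given here, compound 1 therefore stands at the limit, and so does the one other value shown: the limit of > 200000 nM in this assay, at which 2 of the 2 values shown sit.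

Compound 3 `Cc1cc(C(=O)O)ccc1C(=O)N1CCC[C@H](O[C@H](CO)c2cc(Cl)cc(Cl)c2)[C@@H]1c1ccccc1` has not yet been measured in this assay. It differs from compound 1 in one place: a group of 12 heavy atoms (9 carbon, 3 oxygen; one six-membered aromatic ring of carbon only) in place of a group of 6 heavy atoms (4 carbon, 2 nitrogen; one five-membered aromatic ring with 2 hetero atoms), on an amine nitrogen in a ring. Among the compounds with values here, no step between measured compounds is available, and with compound 1 at a limit no size of step can be read from the numbers. The expected step from compound 1 to compound 3 in this assay is a number no higher from compound 1 to compound 3 (the limit leaves the size open), that is none beyond the scatter. For compound 3 the estimate in this assay is 200000 nM, expected between 50000 nM and 600000 nM, most likely reported again only as a limit.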

Compound 3, half-maximal effective concentration: > 200000 nM
Compound 3: a limit, no number; the forecaster's own chance of this, stated with the estimate: 80%; the middle value lies on the limit itself.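

Going by these compounds alone, compound 1 and compound 3 both sit at a limit and not at a number, so no step between them can be read: the limit of > 200000 nM in this assay, at which 3 of the 3 values shown sit. The compounds shown leave open whether any group on the amine nitrogen in the ring of the shared core gives a number rather than a limit.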